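Benzyl for butoxy on the aryl carbamoyl series

A few compounds are considered here, and "the series" means these few. Any claim that something is new, unique, unknown or untested is made for them only; others in the source may bear on it.

Three compounds carry results in a functional assay on SK-MEL-5 cells (Homo sapiens) for inhibition, read by sulforhodamine B assay, with a stated time of 48 h; on this read-out lower numbers stand for stronger inhibition of growth and higher numbers for weaker inhibition of growth. Compound 1 `COc1ccc(NC(=O)Nc2n[nH]c3ccccc23)cc1` sits at the limit of the assay, > 100000 nM, which is a limit and not a number (the limit of > 100000 nM in this assay, at which 1 of the 3 values shown sits). Compound 2 `CCCCOc1ccc(NC(=O)n2nc(N)c3ccccc32)cc1` gives 15200 nM in this assay. Compound 3 `Nc1nn(C(=O)Nc2c(F)cccc2F)c2ccccc12` gives 39700 nM in this assay, a higher number than compound 2 and beyond the usual scatter. Compound 2 therefore stands lowest of the two numbers shown. Going by the values given here, no pair in this set differs in a single place, so no measured step is available to guide the next change.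

Compound 4 `Nc1nn(C(=O)Nc2ccc(Cc3ccccc3)cc2)c2ccccc12` differs from compound 2 by benzyl in place of butoxy on an aromatic carbon. The exchange sits on an aromatic carbon of a six-membered aromatic ring of carbon only, para to a large group. Among the compounds with values here, with no measured step of this kind, the expectation is a step no larger than the scatter, in either direction. The estimate for compound 4 in this assay is 10000 nM, with a range from 3000 nM to 40000 nM. This corresponds to an expected step of a 1.5-fold lower number from compound 2 to compound 4 (0.18 log units; within the scatter).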

Compound 4, concentration for 50% growth inhibition: 2220 nM
Compound 4: the middle estimate sits 4.5-fold (0.65 log units) above what was measured; measured number outside the range, below it.
By their numbers in this assay, from the lowest: compound 4; then compound 2; then compound 3. At a limit, above all of these: compound 1.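

In this assay, going by these compounds alone, this is the first measured step at this position of the aryl carbamoyl series: a 6.8-fold lower number from compound 2 to compound 4 (0.84 log units; beyond the scatter). The position therefore responds to the group it carries, and the change beyond the scatter shows that the oxygen of butoxy is not needed for growth inhibition in this pair. An aromatic ring of carbon only can stand in place of the open chain without loss, on the evidence of this one pair. Nothing measured here bears on why the step has this size.

Within the data shown here, the single exchange removes the oxygen and the chain and adds a ring all at once, so it remains open which of these changes carries the step. A phenoxy group or a pentyl chain on the same aromatic carbon would begin to separate them.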